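Flavone amide series, aryl amide variation, antiproliferative read-out

This account rests on a few compounds, and the source may have more. Where it says the series, first, only, none or still open, it means among the compounds named here.

Measured so far:
compound 1 `Cc1ccccc1C(=O)Nc1cccc(-c2oc3cc(-c4ccc(F)cc4)ccc3c(=O)c2O)c1` gives 17600 nM in a functional assay on A549 cells (Homo sapiens) for antiproliferative activity, read by CCK-8 assay, with a stated time of 72 h; on this read-out lower numbers stand for stronger inhibition and higher numbers for weaker inhibition
compound 2 `COc1ccc(C(=O)Nc2cccc(-c3oc4cc(-c5ccc(F)cc5)ccc4c(=O)c3O)c2)c(F)c1` gives 40000 nM in this assay

Within the data shown here, compound 2 holds the highest number of the two measured compounds; its nearest neighbour is compound 1, and the only single-point step recorded in this assay is a 2.3-fold higher number from compound 1 to compound 2 (0.36 log units; beyond the scatter), a modest shift beyond the scatter from swapping one aryl group on the carbonyl carbon for another.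

Compound 3 `COc1cc(OC)cc(C(=O)Nc2cccc(-c3oc4cc(-c5ccc(F)cc5)ccc4c(=O)c3O)c2)c1` takes the step (3,5-dimethoxyphenyl in place of 2-fluoro-4-methoxyphenyl on a carbonyl carbon). Among the measured compounds shown here, the shared core is untouched; only the aryl group on the amide carbonyl changes, as it did in the one measured step. That step bears on the present one, but it does not show which direction a different substitution pattern on the same ring will take. For the measured compounds named here, the expected step is therefore small, around the scatter boundary, with no firm direction, because a 2.3-fold higher number from compound 1 to compound 2 (0.36 log units; beyond the scatter) is the only guide and it is itself modest.

Compound 3 is expected at 30000 nM, spanning 10000 nM to 90000 nM, which means an expected step of a 1.3-fold lower number from compound 2 to compound 3 (0.12 log units; within the scatter).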

Compound 3, half-maximal inhibitory concentration: 2390 nM
Beside the measured number, compound 3's estimate is 13-fold (1.10 log units) above it; the whole stated range lies above it.
By their numbers in this assay, from the lowest: compound 3; then compound 1; then compound 2.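

In this assay, among these compounds, the aryl group on the amide carbonyl can move the read-out much further than the one earlier step suggested: there is a 17-fold lower number from compound 2 to compound 3 (1.22 log units; beyond the scatter), and also a 7.4-fold lower number from compound 1 to compound 3 (0.87 log units; beyond the scatter). With both steps beyond the scatter, compound 3 is the most potent of the three, and the gain comes from the aryl group alone, since the shared core stays the same. Nothing measured here explains the size of these steps.

The step from compound 2 to compound 3 changes the whole substitution of the ring at once, so the shift cannot be assigned to the loss of the fluorine, to the second methoxy group or to where the methoxy groups sit. As far as these compounds go, whether an amine or a carboxylic acid on this aryl group would keep the gain remains open.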